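The compounds below may be only part of what the source reports. "The series", "measured", "known", "first", "only" and "open" are said of these compounds alone.

Of the compounds shown here, three sharing one core have been measured in an ADME assay on L02 cells (Homo sapiens) for cytotoxicity, read by MTT assay, with a stated time of 72 h; on this read-out lower numbers stand for stronger inhibition and higher numbers for weaker inhibition. Compound 1 `COc1ccc(/C=C2\CNC/C(=C\c3ccc(OC)c(OC)c3)C2=O)cc1OC`, with hydrogen on an amine nitrogen in a ring, gives 15100 nM. Compound 2 `CCCN1C/C(=C\c2ccc(OC)c(OC)c2)C(=O)/C(=C/c2ccc(OC)c(OC)c2)C1`, with propyl at that nitrogen, gives 21000 nM. Compound 3 `COc1ccc(/C=C2\CN(C)C/C(=C\c3ccc(OC)c(OC)c3)C2=O)cc1OC`, with methyl there, gives 18200 nM. Compound 3 therefore sits among these numbers, within the scatter of both other compounds.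

The next compound, compound 4 `CCN1C/C(=C\c2ccc(OC)c(OC)c2)C(=O)/C(=C/c2ccc(OC)c(OC)c2)C1`, has not yet been measured. Its difference from compound 3 is small: methyl in place of hydrogen on a saturated chain carbon bound to an amine nitrogen in a ring. Put simply, methyl on the nitrogen becomes ethyl.

The closest measured evidence is a 1.2-fold lower number from compound 2 to compound 3 (0.06 log units; within the scatter), a step that alters the group at the same chain carbon. Two further steps also change the group on the nitrogen: a 1.2-fold higher number from compound 1 to compound 3 (0.08 log units; within the scatter) and a 1.4-fold higher number from compound 1 to compound 2 (0.14 log units; within the scatter). All three stay within the scatter, so hydrogen, methyl and propyl on this nitrogen cannot be told apart in this assay.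

No step beyond the scatter is therefore expected here, and the estimated step is a 1.1-fold higher number from compound 3 to compound 4 (0.03 log units; within the scatter). The estimated value for compound 4 is 19500 nM, with an expected range from 12500 nM to 30000 nM.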

Compound 4, half-maximal inhibitory concentration: 9800 nM
Estimate against measurement, compound 4: 2.0-fold (0.30 log units) above, outside the stated range (below it).
By their numbers in this assay, from the lowest: compounds 4, 1, 3 and 2 (each within the scatter of the next, the first and the last beyond it).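

Among the compounds shown here, this result gives the first step at this nitrogen that lies beyond the scatter in this assay: a 2.1-fold lower number from compound 2 to compound 4 (0.33 log units; beyond the scatter), a change that shortens the propyl group to ethyl. The separation is modest and holds for this one pair, since ethyl stays within the scatter of the two smaller groups, with a 1.9-fold lower number from compound 3 to compound 4 (0.27 log units; within the scatter) and a 1.5-fold lower number from compound 1 to compound 4 (0.19 log units; within the scatter). Lengthening the group on this nitrogen therefore does not move the numbers steadily in one direction: hydrogen, methyl and ethyl cannot be told apart, and only ethyl and propyl can, so this position is slightly more sensitive to the change than the earlier compounds suggested, though compound 2 and compound 4 remain the only separated pair.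

No supporting measurement is available to explain why ethyl and propyl separate here. The compounds shown also leave open how a longer chain such as butyl, a benzyl group or an acetyl group on this nitrogen would fall in this assay, and whether any of them would extend the small separation seen between ethyl and propyl.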